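Chloro for methyl on compound 1

The compounds below may be only part of what the source reports. "The series", "measured", "known", "first", "only" and "open" are said of these compounds alone.

Measured in an ADME assay on NIH3T3 cells (Mus musculus) for cytotoxicity, read by LDH release, with a stated time of 48 h; a lower number here means a stronger inhibitor, a higher number a weaker inhibitor:
Compound 1 `Cc1ccc(C(=O)c2cc(F)c(OCC(=O)NNC(=O)c3ccc(=O)oc3)c(Cl)c2)cc1`: 32100 nM
Compound 2 `Cc1ccc(C(=O)c2cc(F)c(OCC(=O)NNC(=O)c3cn(C)cn3)c(Cl)c2)cc1`: 94900 nM

Compound 1 stands lowest of these two numbers. Compound 3 `O=C(COc1c(F)cc(C(=O)c2ccc(Cl)cc2)cc1Cl)NNC(=O)c1ccc(=O)oc1` has not yet been measured. Its difference from compound 1 is chloro in place of methyl on an aromatic carbon, para to a large group, so that 4-methylphenyl becomes 4-chlorophenyl. For the measured compounds named here, the only measured step (a 3.0-fold higher number from compound 1 to compound 2 (0.47 log units; beyond the scatter)) lies elsewhere, on a carbonyl carbon, and was modest. It gives a rough scale but says nothing directly about this position. Going by the values given here, no measured step touches the 4-methylphenyl group, so no shift beyond the scatter is expected in this assay and no direction can be given. The estimated step is small (a 1.1-fold lower number from compound 1 to compound 3 (0.03 log units; within the scatter)). Compound 3 is expected near 30000 nM with an estimated range from 12000 nM to 75000 nM as its likely span.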

Compound 3, half-maximal inhibitory concentration: 78600 nM
The estimate for compound 3 lay 2.6-fold (0.42 log units) below the measured number, and the stated range ends below it.
By their numbers in this assay, from the lowest: compound 1; then compounds 3 and 2 (each within the scatter of the next).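

In this assay, for the compounds shown here, the 4-methylphenyl group proved to matter: the change to 4-chlorophenyl gave (a 2.4-fold higher number from compound 1 to compound 3 (0.39 log units; beyond the scatter)), the first measured step at this position. One heavy atom replaced one heavy atom on the aromatic carbon, with no hydrogen-bond donor or acceptor entering or leaving, yet the step lies beyond the scatter and ranks as modest, as does the step on the carbonyl carbon (a 3.0-fold higher number from compound 1 to compound 2 (0.47 log units; beyond the scatter)). Nothing measured here accounts for the shift.

The compounds shown leave open how an amine, a methoxy group or a carboxylic acid would read at this position on the core of compound 1. They also leave open whether chloro in place of methyl gives a similar step when compound 2 is the starting point.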